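This account rests on a few compounds, and the source may have more. Where it says the series, first, only, none or still open, it means among the compounds named here.

Measured in a functional assay on HepG2 cells (Homo sapiens) for antiproliferative activity, read by MTT assay, with a stated time of 24 h; a higher number here means a weaker inhibitor, a lower number a stronger inhibitor:
compound 1 `Sc1nnc(-c2ccc3c(c2)OCCO3)n1-c1ccccc1` gives 60000 nM
compound 2 `Cc1ccccc1CSc1nnc(-c2ccc3c(c2)OCCO3)n1-c1ccccc1` gives 20500 nM
compound 3 `Fc1ccccc1CSc1nnc(-c2ccc3c(c2)OCCO3)n1-c1ccccc1` gives 810 nM

Compound 3 has the lowest number of the three, which makes it the strongest inhibitor so far. It is clearly ahead of both others, with a 25-fold lower number from compound 2 to compound 3 (1.40 log units; beyond the scatter) and a 74-fold lower number from compound 1 to compound 3 (1.87 log units; beyond the scatter) as the measured gaps.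

The next structure, compound 4 `Fc1cccc(F)c1CSc1nnc(-c2ccc3c(c2)OCCO3)n1-c1ccccc1`, differs from compound 3 by one change: fluoro in place of hydrogen on an aromatic carbon here. That is fluoro in place of hydrogen on an aromatic carbon, turning 2-fluorobenzyl into 2,6-difluorobenzyl.

Within the data shown here, no measured step adds a second group to the benzyl. The nearest evidence is a 2.9-fold lower number from compound 1 to compound 2 (0.47 log units; beyond the scatter) for 2-methylbenzyl on sulfur, and a 25-fold lower number from compound 2 to compound 3 (1.40 log units; beyond the scatter) for fluoro in place of methyl. Those steps show that this group can matter a great deal, but they do not give the direction of this change. No step beyond the scatter is therefore expected, and the uncertainty stays wide.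

The expected change is a 1.5-fold higher number from compound 3 to compound 4 (0.17 log units; within the scatter) in this assay as an estimate. For compound 4 the estimated value is 1200 nM, with an expected range of 250 nM to 8000 nM overall.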

Compound 4, half-maximal inhibitory concentration: 2070 nM
For compound 4 the middle estimate is 1.7-fold (0.24 log units) below the measured one; the measured number falls inside the stated range.
By their numbers in this assay, from the lowest: compound 3; then compound 4; then compound 2; then compound 1.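

In this assay, adding a second fluoro to the 2-fluorobenzyl group weakens the compound modestly (a 2.6-fold higher number from compound 3 to compound 4 (0.41 log units; beyond the scatter)), so among the compounds shown, one fluoro on this ring does better than two. The 2,6-difluorobenzyl group still retains a clear advantage over both 2-methylbenzyl (a 9.9-fold lower number from compound 2 to compound 4 (1.00 log units; beyond the scatter)) and hydrogen on the sulfur (a 29-fold lower number from compound 1 to compound 4 (1.46 log units; beyond the scatter)), which shows that this position tolerates the extra fluoro without losing most of the gain. No measurement here explains why the second fluoro costs strength.

On these data alone, it remains open whether any second group would do the same, which a chloro or methoxy group in place of this fluoro could test. Also open, as far as these compounds go, is how an unsubstituted benzyl or a longer alkyl chain on the sulfur would compare.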